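Moving the carbamoyl group around the benzoyl ring

This account rests on a few compounds, and the source may have more. Where it says the series, first, only, none or still open, it means among the compounds named here.

Measured compounds:
compound 1, `NC(=O)c1ccccc1C(=O)N1CCC(N(C2CC2)S(=O)(=O)c2cccc(C(F)(F)F)c2)CC1`, 11%
compound 2, `NC(=O)c1cccc(C(=O)N2CCC(N(C3CC3)S(=O)(=O)c3cccc(C(F)(F)F)c3)CC2)c1`, "not determined" (no result reported)
compound 3, `O=C(c1ccccc1OC(F)(F)F)N1CCC(N(C2CC2)S(=O)(=O)c2cccc(C(F)(F)F)c2)CC1`, "not determined" (no result reported)

The three compounds share a core in which a cyclopropyl-bearing sulfonamide on a piperidine is joined to an aromatic carbonyl. In an assay on cells for inhibition of Voltage-dependent L-type calcium channel subunit alpha-1C (Homo sapiens), read by FLIPR and calcium flux, tested at 1 uM (on this read-out lower numbers stand for a weaker effect and higher numbers for a stronger effect at the one concentration tested), compound 1 gives 11%, a weak effect at the single concentration tested. In this assay compound 2 gives "not determined" (no result reported), and compound 3 likewise gives "not determined" (no result reported), so compound 2 stands without any measured position on this read-out.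

Compound 4, `NC(=O)c1ccc(C(=O)N2CCC(N(C3CC3)S(=O)(=O)c3cccc(C(F)(F)F)c3)CC2)cc1`, differs from compound 2 in one place: 4-carbamoylphenyl in place of 3-carbamoylphenyl on a carbonyl carbon. Within the data shown here, nothing measured bears directly on this step, and the only value available, that of compound 1, is weak. Any step from compound 2 to compound 4 is therefore expected to be small, probably not beyond the usual scatter, with no direction to be read from the data. On that footing compound 4 is estimated at 12% in this assay, expected to lie between 0% and 30%.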

Compound 4, a percentage reported as inhibition, at one concentration (the size of the read-out at that concentration, not a potency): 0%
Estimate against measurement, compound 4: 12 percentage points above, within the range that was stated.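

In this assay, among these compounds, the shift of the carbamoyl group gives the first comparison that can be read at this position: the change to 4-carbamoylphenyl from 2-carbamoylphenyl on a carbonyl carbon gives a number 11 percentage points lower from compound 1 to compound 4 (beyond the scatter). Where the carbamoyl group sits on the benzoyl ring therefore makes a modest difference on this read-out, and compound 4 gives 0%. Nothing available accounts for this difference.

On these data alone, compound 2 has no reported result, so steps involving it cannot be read, and the place of 3-carbamoylphenyl relative to the other two remains open. The compounds shown also leave open how a carboxylic acid or a nitrile in place of the carbamoyl group would behave in this assay.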